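A Longer Acyl Chain on a Catechol Ester

This account rests on a few compounds, and the source may have more. Where it says the series, first, only, none or still open, it means among the compounds named here.

Of the compounds shown here, two have been measured in a toxicity assay on MRC5 cells (Homo sapiens) for inhibition, read by MTT assay, with a stated time of 72 h; on this read-out higher numbers stand for weaker inhibition and lower numbers for stronger inhibition. Compound 1 `CCCCCCCCCCCCSCCc1ccc(OCc2ccc(OC)cc2)c(OCc2ccc(OC)cc2)c1` yields a limit of the assay rather than a number: in this assay compound 1 gives > 50000 nM. Compound 2 `CC(=O)OCCc1ccc(O)c(O)c1` likewise reaches only a limit: in this assay compound 2 gives > 50000 nM. Among the compounds with values here, compound 2 thus stands at the limit of > 50000 nM in this assay, at which 2 of the 2 values shown sit, so no step between measured compounds can be drawn. Compound 3 `CCCC(=O)OCCc1ccc(O)c(O)c1` has not yet been measured in this assay. It differs from compound 2 in one place: ethyl in place of hydrogen on a saturated chain carbon bound to a carbonyl carbon. With both measured values sitting at the limit, no size of step can be read from them, and the step from compound 2 to compound 3 is expected to be none beyond the scatter, which a step that the limit leaves unreadable from compound 2 to compound 3 expresses as the estimate made here. Compound 3 is therefore expected to give about 60000 nM, within a range from 20000 nM to 200000 nM, most likely reported again as a limit.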

Compound 3, half-maximal inhibitory concentration: 71500 nM
Compound 3: the middle estimate sits 1.2-fold (0.08 log units) below what was measured; the measured number falls inside the stated range.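

No size can be read for the step between compound 2 and compound 3, since compound 2 reaches only a limit: the limit of > 50000 nM in this assay, at which 2 of the 3 values shown sit. The compounds shown leave open how acyl chains other than acetyl and propylcarbonyl would read out, as no two of them both give a number.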